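This account rests on a few compounds, and the source may have more. Where it says the series, first, only, none or still open, it means among the compounds named here.

Measured so far:
Compound 1 `COc1ccc(CNc2cc(OC)c(OC)c(OC)c2)cc1C` gives 56800 nM in a functional assay on MGC-803 cells (Homo sapiens) for inhibition, read by MTT assay, with a stated time of 48 h; a lower number here means a stronger inhibitor, a higher number a weaker inhibitor.
Compound 3 `COc1ccc(CNc2cc(OC)c(OC)c(OC)c2)cc1F` gives 39700 nM.
Compound 2 `C#CC(=O)N(Cc1ccc(OC)c(O)c1)c1cc(OC)c(OC)c(OC)c1` gives 170 nM.

Compound 2 stands lowest of the three numbers, far beyond the scatter from both compound 3 and compound 1. Compound 4 `COc1ccc(CN(C(=O)CN=[N+]=[N-])c2cc(OC)c(OC)c(OC)c2)cc1O` differs from compound 2 in one place: azidomethyl in place of ethynyl on a carbonyl carbon. Going by the values given here, the only measured step, a 1.4-fold lower number from compound 1 to compound 3 (0.16 log units; within the scatter), concerns a change on an aromatic carbon between two compounds that differ from compound 2 in several places, so no measured step bears on this change. With nothing to lean on, the expectation for compound 4 is a weaker number than compound 2, with a wide range. Compound 4 is estimated at 1500 nM, between 200 nM and 12000 nM. That expected step is an 8.8-fold higher number from compound 2 to compound 4 (0.95 log units; beyond the scatter).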

Compound 4, half-maximal inhibitory concentration: 120 nM
Estimate against measurement, compound 4: 13-fold (1.10 log units) above; measured number below the stated range.
By their numbers in this assay, from the lowest: compounds 4 and 2 (each within the scatter of the next); then compounds 3 and 1 (each within the scatter of the next).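

In this assay azidomethyl in place of ethynyl on a carbonyl carbon gives a 1.4-fold lower number from compound 2 to compound 4 (0.15 log units; within the scatter) and so leaves the two compounds indistinguishable. For this one pair, the position takes a group of 4 heavy atoms, with no triple bond, in place of one of 2 heavy atoms with no measurable change in the number. Nothing available explains why the two groups read alike. The compounds shown leave open whether an amine, a carboxylic acid or a longer chain on this carbonyl carbon would also read alike.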